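Permeability of Three Measured Compounds and One Untested Analog

This account rests on a few compounds, and the source may have more. Where it says the series, first, only, none or still open, it means among the compounds named here.

Measured compounds:
compound 1: `Fc1ccc(Cc2ccc3c(NCCCNCc4ccco4)ccnc3c2)c(Cl)c1`, 23 10^-6 cm/s
compound 2: `c1coc(CNCCCNc2ccnc3cc(CC4CCCCC4)ccc23)c1`, 23 10^-6 cm/s
compound 3: `COc1cccc(CNCCCNc2ccnc3cc(CC4CCCCC4)ccc23)c1O`, 23 10^-6 cm/s

Three compounds of this series have been run in an ADME assay for permeability, using PAMPA, with a stated time of 30 min, at pH 7.4; a lower number here means that the compound crosses the layer more slowly, a higher number that the compound crosses the layer faster. Compound 1 gives 23 10^-6 cm/s. Compound 2 gives 23 10^-6 cm/s. Compound 3 gives 23 10^-6 cm/s. All three stand level with one another in this assay.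

Two single changes link the measured compounds. From compound 2 to compound 1 the change is 2-chloro-4-fluorophenyl in place of cyclohexyl on a saturated chain carbon bound to an aromatic carbon, and the step in this assay was no change at the digits printed from compound 2 to compound 1 (within the scatter). From compound 2 to compound 3 the cores differ by 2-hydroxy-3-methoxyphenyl in place of furan-2-yl on a saturated chain carbon bound to an amine nitrogen, and the step was no change at the digits printed from compound 2 to compound 3 (within the scatter).

The untested compound 4 `COc1cccc(CNCCCNc2ccnc3cc(Cc4ccc(F)cc4Cl)ccc23)c1O` differs from compound 3 by 2-chloro-4-fluorophenyl in place of cyclohexyl on a saturated chain carbon bound to an aromatic carbon. This is the same change that was already made from compound 2 to compound 1, at the same place, and it occurs twice among the compounds shown. The earlier instance left the read-out where it was.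

The step from compound 3 to compound 4 in this assay is therefore expected to be no change at the digits printed from compound 3 to compound 4 (within the scatter), because the identical change from compound 2 to compound 1 gave no change at the digits printed from compound 2 to compound 1 (within the scatter). That expectation rests on one measured pair only. Compound 4 is estimated at 23 10^-6 cm/s in this assay, with a likely range from 12 10^-6 cm/s to 40 10^-6 cm/s.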

Compound 4, apparent permeability: 23 10^-6 cm/s
Compound 4: middle estimate and measured number agree at the digits printed; measured number inside the range.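

In this assay, 2-chloro-4-fluorophenyl in place of cyclohexyl on a saturated chain carbon bound to an aromatic carbon gave no change at the digits printed from compound 3 to compound 4 (within the scatter), and this result matched the earlier instance of the change on a second core: the same change on two cores in this assay, no change at the digits printed (within the scatter) from compound 2 to compound 1 and no change at the digits printed (within the scatter) from compound 3 to compound 4, 1.0-fold (0.00 log units) apart, within the scatter of two such steps. Likewise, 2-hydroxy-3-methoxyphenyl in place of furan-2-yl on a saturated chain carbon bound to an amine nitrogen gave no change at the digits printed from compound 1 to compound 4 (within the scatter), and this too matched its earlier instance: the same change on two cores in this assay, no change at the digits printed (within the scatter) from compound 2 to compound 3 and no change at the digits printed (within the scatter) from compound 1 to compound 4, 1.0-fold (0.00 log units) apart, within the scatter of two such steps. Within these four compounds, each change therefore reads the same on both cores, but since neither change moved the read-out, this agreement shows only that a null result repeated and does not show that a change with a real effect would carry over in the same way, or that either change would stay silent on any other core.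

The compounds shown leave open whether a carboxylic acid or an amine in place of cyclohexyl, or a longer chain, would shift the read-out at all. They also leave open whether any such shift would keep its size from one core to another.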